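The source may report more compounds than this note shows. Statements on the series, on what has been measured and on what is new or still open speak of the compounds shown alone.

Series notes. Two compounds of the shared core carry numbers in a functional assay on HL-60 cells (Homo sapiens) for antiproliferative activity, with a stated time of 24 h (on this read-out lower numbers stand for stronger inhibition and higher numbers for weaker inhibition), so far. Compound 1 `NC(=O)c1c(NC(=O)c2ccc(C(F)(F)F)cc2)sc2c1CCN(Cc1ccc(Cl)cc1Cl)C2` gives 14900 nM in this assay. Compound 2 `COc1ccccc1C(=O)Nc1sc2c(c1C(N)=O)CCN(C(=S)Nc1ccccc1Cl)C2` gives 20800 nM in this assay, the higher of the two numbers; the gap to compound 1 lies within the scatter, so the two stand level. Compound 3 `NC(=O)c1c(NC(=O)c2ccc(C(F)(F)F)cc2)sc2c1CCN(C(=S)Nc1ccccc1Cl)C2` is the next member, not yet measured in this assay. It differs from compound 2 by 4-(trifluoromethyl)phenyl in place of 2-methoxyphenyl on a carbonyl carbon and thereby carries the same benzamide as compound 1 together with the thiourea of compound 2. Within the data shown here, no step between measured compounds covers this change. With both measured values level and weak, no shift beyond the scatter in either direction is expected; the step of a 1.3-fold lower number from compound 2 to compound 3 (0.11 log units; within the scatter) is the estimated size. Compound 3 is expected to give 16000 nM in this assay, within the range 6000 nM to 45000 nM.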

Compound 3, half-maximal inhibitory concentration: 36100 nM
Estimate against measurement, compound 3: 2.3-fold (0.35 log units) below; the range from low to high includes it.
By their numbers in this assay, from the lowest: compounds 1, 2 and 3 (each within the scatter of the next, the first and the last beyond it).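

The step of a 1.7-fold higher number from compound 2 to compound 3 (0.24 log units; within the scatter) shows that, with the thiourea held fixed, 4-(trifluoromethyl)phenyl and 2-methoxyphenyl on a carbonyl carbon are not told apart in this assay. Among these compounds, with 4-(trifluoromethyl)phenyl on that carbonyl in both compounds, the change on an amine nitrogen in a ring gives a 2.4-fold higher number from compound 1 to compound 3 (0.38 log units; beyond the scatter), the only step beyond the scatter, and a modest one that rests on this single pair. No supporting data on the origin of either step are available here.

Open, on these data alone, is whether a urea in place of the thiourea, or a simple alkyl chain on the amine nitrogen in a ring, would shift the number in this assay by more. Also open is whether an unsubstituted phenyl or a pyridine on the carbonyl carbon would separate from the two aryl groups shown.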